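Swapping the Sulfonamide for a Cyanocyclopropyl Group

This account rests on a few compounds, and the source may have more. Where it says the series, first, only, none or still open, it means among the compounds named here.

Measured compounds:
compound 1 `CN1C(=O)C(c2cccc(C(F)(F)F)c2)N(C)c2nc(Nc3ccc(S(N)(=O)=O)cc3)ncc21`: 2710 nM
compound 2 `CN1C(=O)C(c2ccccc2Br)N(C)c2nc(Nc3ccc(S(N)(=O)=O)cc3)ncc21`: 57 nM
compound 3 `CCNS(=O)(=O)c1ccc(Nc2ncc3c(n2)N(C)C(c2ccccc2C)C(=O)N3C)cc1`: 119 nM

All three numbers come from an assay on Sf9 cells for inhibition of serine/threonine-protein kinase 4 (Homo sapiens), read by luminescence and ADP-Glo, with a stated time of 1 h, in the presence of a further agent that is not named here; a lower number here means a stronger inhibitor, a higher number a weaker inhibitor. Compound 3 sits in the middle of the three: compound 2 lies beyond the scatter below it, while compound 1 lies far above it, also beyond the scatter. Among the compounds with values here, the only step measured between two compounds that differ in a single place is a 48-fold lower number from compound 1 to compound 2 (1.68 log units; beyond the scatter), and that step concerns the group on the saturated ring carbon of the shared core.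

Compound 4 `Cc1ccccc1C1C(=O)N(C)c2cnc(Nc3ccc(C4(C#N)CC4)cc3)nc2N1C` differs from compound 3 at a different place: 1-cyanocyclopropyl in place of ethylsulfamoyl on an aromatic carbon. Within the data shown here, no measured step touches this part of the molecule, so the data give no direct guide to how large the change will be or in which direction it will go. The expectation therefore rests mainly on the value of compound 3, 119 nM, with a wide allowance for the unknown.

Compound 4 is expected to give 300 nM, with a range from 60 nM to 1500 nM. That estimate corresponds to an expected step of a 2.5-fold higher number from compound 3 to compound 4 (0.40 log units; beyond the scatter). The breadth of the range reflects the absence of any measured step of this kind.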

Compound 4, half-maximal inhibitory concentration: 256 nM
The estimate for compound 4 lay 1.2-fold (0.07 log units) above the measured number; measured number inside the range.
By their numbers in this assay, from the lowest: compound 2; then compound 3; then compound 4; then compound 1.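

In this assay, within the data shown here, putting 1-cyanocyclopropyl in place of ethylsulfamoyl on this aromatic carbon gives a 2.2-fold higher number from compound 3 to compound 4 (0.33 log units; beyond the scatter), the only measured step at this part of the molecule. The entering group carries no sulfur and no hydrogen-bond donor, yet compound 4 still reads 256 nM, so within this pair the number moves only modestly when the ethylsulfamoyl group is gone, a much smaller shift than a 48-fold lower number from compound 1 to compound 2 (1.68 log units; beyond the scatter) at the saturated ring carbon. Nothing measured here explains why the number rises with this swap.

The step treats the cyano group and the three-membered ring as a single unit, so a plain nitrile without the ring, or a cyclopropyl group without the nitrile, would be needed to tell their shares apart. Also open, from the compounds shown here alone, is what a carboxylic acid or a morpholine ring would give on this aromatic carbon, and whether the step keeps its size when 2-bromophenyl rather than the group of compound 3 sits on the saturated ring carbon.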